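Sulfonamide nitrogen substitution in a thiourea antiproliferative series

The source may report more compounds than this note shows. Statements on the series, on what has been measured and on what is new or still open speak of the compounds shown alone.

Measured so far:
compound 1 `NS(=O)(=O)c1ccc(N/C(S)=N\c2ccnc3cc(C(F)(F)F)ccc23)cc1`: 52200 nM
compound 2 `Cc1noc(NS(=O)(=O)c2ccc(N/C(S)=N\c3ccnc4cc(C(F)(F)F)ccc34)cc2)c1C`: 36800 nM

In a functional assay on HepG2 cells (Homo sapiens) for antiproliferative activity, read by sulforhodamine B assay, with a stated time of 48 h (on this read-out lower numbers stand for stronger inhibition and higher numbers for weaker inhibition), compound 1 gives 52200 nM, the highest of the two numbers; compound 2 is the nearest with 36800 nM, and the step of a 1.4-fold lower number from compound 1 to compound 2 (0.15 log units; within the scatter) stays within the scatter. Compound 3 `COc1cc(NS(=O)(=O)c2ccc(N/C(S)=N\c3ccnc4cc(C(F)(F)F)ccc34)cc2)nc(OC)n1` differs from compound 1 by 2,6-dimethoxypyrimidin-4-yl in place of hydrogen on a sulfonamide nitrogen. Among the compounds with values here, the only measured step that bears on this change is the substitution on the same sulfonamide nitrogen, a 1.4-fold lower number from compound 1 to compound 2 (0.15 log units; within the scatter), which did not move the number beyond the scatter. Within the data shown here, a different group enters in compound 3, so that single step is the only guide, and no step beyond the scatter is expected in this assay in either direction. Compound 3 is therefore estimated at 42000 nM, with a range of 15000 nM to 110000 nM. The expected step of a 1.2-fold lower number from compound 1 to compound 3 (0.09 log units; within the scatter) is thus within the scatter.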

Compound 3, half-maximal inhibitory concentration: 76700 nM
Beside the measured number, compound 3's estimate is 1.8-fold (0.26 log units) below it; the range from low to high includes it.
By their numbers in this assay, from the lowest: compounds 2, 1 and 3 (each within the scatter of the next, the first and the last beyond it).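

In this assay, 2,6-dimethoxypyrimidin-4-yl on the sulfonamide nitrogen gives a 1.5-fold higher number from compound 1 to compound 3 (0.17 log units; within the scatter), so a second substituent of a different ring type also stays level with the unsubstituted sulfonamide. Within the data shown here, exchanging the two substituents on that nitrogen gives a 2.1-fold higher number from compound 2 to compound 3 (0.32 log units; beyond the scatter), the first step beyond the scatter, though a modest one: the choice of group here can separate two substituted compounds, even though neither is separated from compound 1. Nothing available explains the difference between these two groups.

From the compounds shown here alone, whether a simple methyl, an amine-bearing chain or a carboxylic acid on the sulfonamide nitrogen would move the number beyond the scatter from compound 1 remains open. Also open, going by these compounds, is whether a nitrile in place of the trifluoromethyl on the shared core would produce a larger step than any change at this nitrogen.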